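Aryl guanidines at the sigma-1 receptor: a methyl analogue

This account rests on a few compounds, and the source may have more. Where it says the series, first, only, none or still open, it means among the compounds named here.

Working notes on two measured guanidines and one to be measured. Compound 1 `CCc1cccc(NC(=N)Nc2cccc3ccccc23)c1` and compound 2 `N=C(Nc1ccccc1I)Nc1cccc2ccccc12` share a core that differs only in the substituted phenyl on one amine nitrogen. In an assay on membranes from brain (Cavia porcellus) for binding affinity to Sigma non-opioid intracellular receptor 1 (Homo sapiens), read by radioligand binding (on this read-out lower numbers stand for stronger inhibition and higher numbers for weaker inhibition), compound 1 gives 54 nM. In this assay compound 2 gives 40 nM, and the gap to compound 1 lies within the usual scatter, so the two numbers are read as equivalent.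

Compound 3 `Cc1cccc(NC(=N)Nc2cccc3ccccc23)c1` is the next member, not yet measured. It is obtained from compound 2 by the change (3-methylphenyl in place of 2-iodophenyl on an amine nitrogen), that is 3-methylphenyl in place of 2-iodophenyl on an amine nitrogen. Within the data shown here, no step between measured compounds is known here, so nothing sets a direction; the two measured numbers fall close together, and a step within the scatter, in either direction, is expected.

Compound 3 is therefore estimated at 60 nM in this assay, with a range from 25 nM to 150 nM. The expected step is a 1.5-fold higher number from compound 2 to compound 3 (0.18 log units; within the scatter).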

Compound 3, half-maximal inhibitory concentration: 75 nM
For compound 3 the middle estimate is 1.3-fold (0.10 log units) below the measured one; measured number inside the range.
By their numbers in this assay, from the lowest: compounds 2, 1 and 3 (each within the scatter of the next).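

In this assay, 3-methylphenyl in place of 2-iodophenyl on an amine nitrogen gives a 1.9-fold higher number from compound 2 to compound 3 (0.27 log units; within the scatter) and hydrogen in place of methyl on a saturated chain carbon bound to an aromatic carbon gives a 1.4-fold higher number from compound 1 to compound 3 (0.14 log units; within the scatter) as the first steps read in this series. Neither change moves the number beyond the scatter, so among these three compounds the substituted phenyl on this nitrogen can carry iodine or a small carbon chain with the numbers remaining equivalent. No measured property is available to account for this result.

Still open, going by these compounds, is whether an amine, a carboxylic acid or a longer chain on this phenyl would give a step beyond the scatter. The three compounds also leave open whether any change on this phenyl separates the numbers at all.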